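Pyridin-4-yl in place of 2-bromophenyl: working notes

This account rests on a few compounds, and the source may have more. Where it says the series, first, only, none or still open, it means among the compounds named here.

Within the data shown here, in an ADME assay on Vero cells (Chlorocebus sabaeus) for cytotoxicity, read by MTT assay (a higher number here means a weaker inhibitor, a lower number a stronger inhibitor), compound 2 `C=CCOc1cc(OC)c(C(=O)/C=C/c2ccccc2Br)c(OCC=C)c1` gives 13900 nM as the only number so far. Compound 1 `C=CCOc1cc(OC)c(C(=O)/C=C/C=C/c2ccccc2)c(OCC=C)c1` reads "not determined" (no result reported) and offers no comparison. Compound 3 `COc1ccc(/C=C/C(=O)c2c(O)cc(O)cc2OC)cc1` reads "not determined" (no result reported) and offers none either, so compound 2 cannot yet be ranked. Compound 4 `C=CCOc1cc(OC)c(C(=O)/C=C/c2ccncc2)c(OCC=C)c1` differs from compound 2 in one place. The change pyridin-4-yl in place of 2-bromophenyl on a double-bonded chain carbon bound to a double-bonded chain carbon puts pyridin-4-yl in place of 2-bromophenyl on a double-bonded chain carbon bound to a double-bonded chain carbon. Among the measured compounds shown here, no measured step bears on this change. The estimated step of a 1.4-fold higher number from compound 2 to compound 4 (0.16 log units; within the scatter) is expected to be modest, towards a higher number in this assay and little beyond the scatter. For compound 4 the estimated value is 20000 nM with an expected range from 7000 nM to 60000 nM at this stage.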

Compound 4, half-maximal inhibitory concentration: 2800 nM
Beside the measured number, compound 4's estimate is 7.1-fold (0.85 log units) above it; the whole stated range lies above it.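

In this assay, among these compounds, this place on the chain responds to the exchange, with a 5.0-fold lower number from compound 2 to compound 4 (0.70 log units; beyond the scatter) as the first readable step and a move towards a stronger inhibitor. One exchange cannot separate the departure of the bromine from the entry of the ring nitrogen. No measurement shown accounts for the step. Going by these compounds, whether the ring nitrogen alone carries the step remains open, as pyridin-3-yl and plain phenyl do not appear here. Also open, on these data alone, is how an amine or a carboxylic acid on the ring at this place would read.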